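The source may hold more compounds than are shown below. What is called first, only, known or untested is meant among the compounds shown, and "the series" means these compounds.

Measured compounds:
compound 1, `CC(C)(C)C1=NN(c2cccc(Cl)c2)C(c2ccc(O)cc2)C1`, 96.8%;
compound 2, `CC(C)(C)C1=NN(c2cccc(F)c2)C(c2ccc(O)cc2)C1`, 98.1%;
compound 3, `CC(C)(C)C1=NN(c2ccc(Cl)cc2)C(c2ccc(F)cc2)C1`, 0%.

All three were run in an assay on isolated protein for inhibition of protein kinase C zeta type (Homo sapiens), with a stated time of 4 min, tested at 62.5 uM; on this read-out higher numbers stand for more inhibition at the one concentration tested (going by the name of the read-out) and lower numbers for less inhibition. Compound 1 and compound 2 sit close together, the step of a number 1.3 percentage points lower from compound 2 to compound 1 (within the scatter) being (chloro in place of fluoro on an aromatic carbon). Compound 3 stands far below both; how its core differs from that of compound 2 is not broken down here.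

The unmeasured compound 4, `CC(C)(C)C1=NN(c2ccc(Cl)cc2)C(c2ccc(Cl)cc2)C1`, is reached from compound 3 by chloro in place of fluoro on an aromatic carbon. This is the same kind of change as that from compound 2 to compound 1, but the place differs: there the chloro entered meta to a large group, here it enters para to a large group. Going by the values given here, the only measured instance of this change hardly moved this assay, so the step from compound 3 to compound 4 is expected to be small as well, roughly a number 4 percentage points higher from compound 3 to compound 4 (within the scatter), because compound 3 itself reads 0% and leaves little room downward. Compound 4 is therefore estimated at about 4%, likely between 0% and 25%.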

Compound 4, a percentage reported as inhibition, at one concentration (the size of the read-out at that concentration, not a potency): 11.8%
Beside the measured number, compound 4's estimate is 7.8 percentage points below it; measured number inside the range.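

In this assay, going from 4-fluorophenyl to 4-chlorophenyl gives a number 11.8 percentage points higher from compound 3 to compound 4 (beyond the scatter), a modest step that leaves compound 4 low on this read-out. Set beside the only other instance of this change, the step does not differ by more than two such steps would scatter: the same change on two cores in this assay, a number 1.3 percentage points lower (within the scatter) from compound 2 to compound 1 and a number 11.8 percentage points higher (beyond the scatter) from compound 3 to compound 4, 13.1 percentage points apart, within the scatter of two such steps. So, as far as these two pairs go, the change carries from one core to the other without a measurable difference, but two pairs, each read at a single concentration, one near the top of the read-out and one near the bottom, do not show that the step is the same across the series, nor how potency moves.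

Open, as far as these compounds go, is how an amine, a methoxy group or a carboxylic acid would read in place of the halogen at the position para to a large group. Also open, from the compounds shown here alone, is whether any such group would lift the core of compound 3 from the low end of this assay.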